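The compounds below may be only part of what the source reports. "The series", "measured", "known", "first", "only" and "open" are said of these compounds alone.

Working notes on the series. Three compounds have been run in an assay on isolated protein for inhibition of G protein-coupled receptor kinase 5 (Homo sapiens), read by TR-FRET, with stated times of 10 min and 1 h; a lower number here means a stronger inhibitor, a higher number a weaker inhibitor. Compound 1 `CN(C)COc1cccc(-c2cnc(N)c(-c3nc4cccc(-c5ccccn5)c4o3)c2)c1` gives 5100 nM. Compound 2 `CCc1ccc2nc(-c3cc(-c4cnn(C5CCNCC5)c4)cnc3N)oc2c1O` gives 3400 nM. Compound 3 `Nc1ncc(-c2cnn(C3CCNCC3)c2)cc1-c1nc2ccc(-c3cn[nH]c3)cc2o1` gives 1780 nM, the lowest of the three numbers; its gap to compound 2 lies within the scatter, so no order between those two can be read, while its gap to compound 1 lies beyond the scatter. Within the data shown here, no pair of measured compounds differs in only one place, so no step can be separated out and no pattern is claimed beyond the three numbers themselves.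

Compound 4 `COc1ccc(C(=O)Nc2ccc3nc(-c4cc(-c5cnn(C6CCNCC6)c5)cnc4N)oc3c2)cc1` is the next one to be measured in this assay. It differs from compound 3 in one place: ((4-methoxyphenyl)carbonyl)amino in place of 1H-pyrazol-4-yl on an aromatic carbon. Among the measured compounds shown here, no measured step shows what such an exchange does in this assay, so the expectation rests on compound 3 alone. The expected step from compound 3 to compound 4 in this assay is a 1.2-fold lower number from compound 3 to compound 4 (0.07 log units; within the scatter), that is, a change not clearly beyond the scatter in either direction, with a wide range owing to the lack of any comparable step. On that basis compound 4 is estimated at 1500 nM, between 400 nM and 6000 nM.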

Compound 4, half-maximal inhibitory concentration: 2090 nM
For compound 4 the middle estimate is 1.4-fold (0.14 log units) below the measured one, and the stated range covers the measured number.
By their numbers in this assay, from the lowest: compounds 3, 4, 2 and 1 (each within the scatter of the next, the first and the last beyond it).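

In this assay, the exchange on an aromatic carbon of the fused system gives a 1.2-fold higher number from compound 3 to compound 4 (0.07 log units; within the scatter), so this position holds ((4-methoxyphenyl)carbonyl)amino, with 11 heavy atoms, in place of 1H-pyrazol-4-yl, with 5, without a step beyond the scatter. The change also replaces a five-membered aromatic ring with 2 hetero atoms by a six-membered aromatic ring of carbon only and brings in a double bond outside aromatic rings, yet the two numbers do not separate these groups. No available measurement accounts for this result.

A single step at this position cannot show whether the methoxy group on the entering ring or the carbonyl-and-amino link has any bearing on the number, and a plain phenylcarbonylamino group or a phenyl attached directly to the ring would be needed to separate those parts. Also open, on these data alone, is whether a small group such as an amine, a carboxylic acid or a methyl at this aromatic carbon would give a step beyond the scatter, in either direction.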